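The compounds below may be only part of what the source reports. "The series", "measured", "known", "first", "only" and "open" are said of these compounds alone.

Compound 1 `O=C1CC(CCc2ccccc2)[S+]([O-])S1`: 24800 nM
Compound 2 `CC1(C)O[C@H]([C@H]2COC(C)(C)O2)[C@@H](C2CC(=O)SS2)O1`: 16900 nM

Both numbers come from a functional assay on HeLa cells (Homo sapiens) for cytotoxicity, read by MTT assay, in the presence of a further agent that is not named here; a higher number here means a weaker inhibitor, a lower number a stronger inhibitor. Compound 2 stands level with compound 1 within the scatter, and with only these two values its place in the series is poorly defined. Compound 3 `CC1(C)O[C@H]([C@H]2COC(C)(C)O2)[C@@H](C2CC(=O)S[S+]2[O-])O1` is still to be measured. It departs from compound 2 on a saturated ring carbon: a group of 7 heavy atoms (3 carbon, 2 oxygen, 2 sulfur; one five-membered non-aromatic ring with 2 hetero atoms) in place of a group of 6 heavy atoms (3 carbon, 1 oxygen, 2 sulfur; one five-membered non-aromatic ring with 2 hetero atoms), on a saturated ring carbon. Within the data shown here, no measured pair isolates this change. Compound 1 already carries the group of 7 heavy atoms, though on another remainder, and it gives 24800 nM, so a large move is not expected. In this assay the expected outcome is no step beyond the scatter, with no firm direction. The expected step is a 1.1-fold lower number from compound 2 to compound 3 (0.05 log units; within the scatter). For compound 3 the estimated value is 15000 nM, with an expected range of 5500 nM to 40000 nM.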

Compound 3, half-maximal inhibitory concentration: 12600 nM
Compound 3: the middle estimate sits 1.2-fold (0.08 log units) above what was measured, and the stated range covers the measured number.
By their numbers in this assay, from the lowest: compounds 3, 2 and 1 (each within the scatter of the next).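

In this assay, the group of 7 heavy atoms in place of the group of 6 heavy atoms, on a saturated ring carbon of the shared core, reads as a 1.3-fold lower number from compound 2 to compound 3 (0.13 log units; within the scatter). Among these compounds, this is the first pair that isolates the exchange, and on this core the two five-membered rings with 2 hetero atoms cannot be told apart in this assay. Nothing on hand bears on why compound 2 and compound 3 stand level.

Going by these compounds, the exchange is read on one core only, so whether it stays within the scatter on the core of compound 1 remains open. Also open, on these data alone, is how a group of another kind, such as an amine or a carboxylic acid, would read on this saturated ring carbon.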